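Cytotoxicity Stays Beyond the Assay Limit Throughout

This account rests on a few compounds, and the source may have more. Where it says the series, first, only, none or still open, it means among the compounds named here.

Compound 1 `CC(C)N(Cc1cccc(OCCCCCC(=O)O)c1)C(=O)c1ccc(-c2ccoc2)cc1` — in an ADME assay on HepG2 cells (Homo sapiens) for cytotoxicity, read by CellTiter-Glo and resazurin assay, with a stated time of 72 h (a lower number here means that less compound is needed, a higher number that more compound is needed for the effect), compound 1 gives > 26000 nM, which is a limit of the assay and not a number.
Compound 2 `COc1cc(F)cc(-c2ccc(C(=O)N(Cc3cccc(OCCCCCC(=O)O)c3)C(C)C)cc2)c1` — compound 2 gives > 26000 nM, again a limit of the assay.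
Compound 3 `CCOC(=O)CCCCCOc1cccc(CN(C(=O)c2ccc(-c3ccoc3)cc2)C(C)C)c1` — compound 3 gives > 26000 nM, also a limit of the assay.

Compound 3 therefore stands nowhere in particular on the scale: its result is only a limit, and the two other results shown are limits as well, so all three sit together at the limit of > 26000 nM in this assay, at which 3 of the 3 values shown sit. Compound 4 `CCOC(=O)CCCCCOc1cccc(CN(C(=O)c2ccc(-c3cc(F)cc(OC)c3)cc2)C(C)C)c1` arises from compound 3 by 3-fluoro-5-methoxyphenyl in place of furan-3-yl on an aromatic carbon.

Among the measured compounds shown here, two measured steps bear on this change. The same swap of ring was already made once, from compound 1 to compound 2, and gave a step that the two limits leave unreadable from compound 1 to compound 2. The other step, which turns the acid of compound 1 into the ester of compound 3, gave a step that the two limits leave unreadable from compound 1 to compound 3. Neither step yields a readable size, so no direction can be claimed for this assay, and nothing beyond the scatter can be expected. Compound 4 is expected to give a step that the limit leaves unreadable from compound 3 to compound 4. The estimate for compound 4 is 40000 nM, with a range from 26000 nM to 100000 nM, most likely reported only as a limit.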

Compound 4, half-maximal effective concentration: > 26000 nM
Compound 4: only a limit was reported; the forecaster's own chance of this, stated with the estimate: 85%; the middle value does not contradict the limit.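

In this assay compound 4 gives > 26000 nM, which is a limit of the assay and not a number. Its steps from compound 3 and from compound 2 therefore cannot be read: the limit of > 26000 nM in this assay, at which 4 of the 4 values shown sit.

Still open, going by these compounds, is whether 3-fluoro-5-methoxyphenyl in place of furan-3-yl, or ethyl on the acid, changes this result at all.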